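Lipophilicity notes on compounds 1 to 4

The source may report more compounds than this note shows. Statements on the series, on what has been measured and on what is new or still open speak of the compounds shown alone.

Measured so far:
compound 1 `Nc1nc(N)nc(-c2cc(Br)ccc2Br)n1`, a physicochemical assay for lipophilicity (a lower number here means a more polar compound, a higher number a more lipophilic compound), 2.09
compound 2 `Nc1nc(N)nc(-c2cc(C(F)(F)F)ccc2Cl)n1`, 2.27
compound 3 `COc1ccc(Br)cc1-c1nc(N)nc(N)n1`, 1.53

Compound 3 stands lowest of the three numbers. Its nearest neighbour is compound 1, which lies higher by a margin beyond the scatter, and compound 2 lies further above still. Among the compounds with values here, the only single-point step among the measured compounds, a number 0.56 log units lower from compound 1 to compound 3 (beyond the scatter), is the one that produced compound 3 from compound 1, and it is a modest drop.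

Compound 4 `Nc1nc(N)nc(-c2cc(Br)ccc2Cl)n1` is not yet measured. It differs from compound 3 as follows: chloro in place of methoxy on an aromatic carbon. Within the data shown here, this is the reverse kind of move to the one from compound 1 to compound 3, since it again exchanges the group on this aromatic carbon and removes the methoxy that accompanied the drop. An upward step beyond the scatter is therefore expected, of about the size seen in a number 0.56 log units lower from compound 1 to compound 3 (beyond the scatter), so that compound 4 is estimated to give 1.95 with a range from 1.7 to 2.25. The expected step of a number 0.42 log units higher from compound 3 to compound 4 (beyond the scatter) is set slightly short of a full return because compound 1 gives 2.09 with bromo rather than chloro in that place, while compound 2 gives 2.27 with chloro there but a different group para to it.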

Compound 4, partition coefficient: 2.04
Beside the measured number, compound 4's estimate is 0.09 log units below it, and the stated range covers the measured number.
By their numbers in this assay, from the lowest: compound 3; then compounds 4, 1 and 2 (each within the scatter of the next).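

Read in this assay, the move from methoxy to chloro on the aromatic carbon ortho to a group of 8 heavy atoms and para to a bromo group gives a number 0.51 log units higher from compound 3 to compound 4 (beyond the scatter), which pairs with a number 0.56 log units lower from compound 1 to compound 3 (beyond the scatter) and leaves compound 3 apart from both halogen-bearing compounds by steps beyond the scatter. The two halogens at this place are not told apart, as the exchange of bromo for chloro gives a number 0.05 log units lower from compound 1 to compound 4 (within the scatter), so the earlier comparison with bromo alone now extends to chloro. The series also gains a first one-place comparison involving trifluoromethyl, where bromo in its place gives a number 0.23 log units lower from compound 2 to compound 4 (within the scatter), and this exchange on an aromatic carbon likewise does not separate the two compounds.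

No evidence on the origin of these steps is available for this set. Going by these compounds, with only methoxy, chloro and bromo compared at this place, the outcome with a hydroxyl, an amine or an ethoxy group there remains open, and so does whether the same steps would hold with a group other than bromo or trifluoromethyl at the second substituted carbon.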